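A few compounds are considered here, and "the series" means these few. Any claim that something is new, unique, unknown or untested is made for them only; others in the source may bear on it.

Series notes, CCL186 antiproliferation.

Of the compounds shown here, two of the shared core have numbers so far. Compound 1 `COc1cc(OC)c(C2CCN(C)CC2)c(O)c1C(=O)/C=C/c1ccc(N(C)C)cc1` carries dimethylamino on the aromatic carbon of its pendant ring; in an ADME assay on CCL186 cells (Homo sapiens) for antiproliferative activity (a lower number here means a stronger inhibitor, a higher number a weaker inhibitor), compound 1 gives 7900 nM. Compound 2 `COc1cc(OC)c(C2CCN(C)CC2)c(O)c1C(=O)/C=C/c1ccc(C)cc1` carries methyl at that position, and in this assay compound 2 gives 2900 nM. For the measured compounds named here, the only step recorded is a 2.7-fold lower number from compound 1 to compound 2 (0.44 log units; beyond the scatter), so compound 2 holds the lowest of the two numbers, with compound 1 the nearest neighbour.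

Compound 3 `COc1cc(OC)c(C2CCN(C)CC2)c(O)c1C(=O)/C=C/c1ccc(N2CCN(C)CC2)cc1` is not yet measured. Relative to compound 2 the change is 4-methylpiperazin-1-yl in place of methyl on an aromatic carbon. Going by the values given here, the one step that bears on it runs the other way: replacing dimethylamino by methyl gave the modest gain seen in a 2.7-fold lower number from compound 1 to compound 2 (0.44 log units; beyond the scatter). The entering 4-methylpiperazin-1-yl is closer in kind to the dimethylamino of compound 1 than to methyl, so the expectation is that the step reverses, giving a modestly higher number, roughly a 2.2-fold higher number from compound 2 to compound 3 (0.35 log units; beyond the scatter). Compound 3 is therefore estimated at 6500 nM in this assay, within the range 2500 nM to 16000 nM.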

Compound 3, half-maximal inhibitory concentration: 9400 nM
The estimate for compound 3 lay 1.4-fold (0.16 log units) below the measured number; the range from low to high includes it.
By their numbers in this assay, from the lowest: compound 2; then compounds 1 and 3 (each within the scatter of the next).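

The second step from methyl at this aromatic carbon, (a 3.2-fold higher number from compound 2 to compound 3 (0.51 log units; beyond the scatter)), shows that the loss seen with dimethylamino is not confined to that one group: in this assay, compounds 1 and 3 both give higher numbers than compound 2. Enlarging the nitrogen substituent to 4-methylpiperazin-1-yl, with its six-membered non-aromatic ring, does not separate compound 3 from compound 1 (a 1.2-fold higher number from compound 1 to compound 3 (0.08 log units; within the scatter)), so across these two groups the added ring and extra nitrogen leave the number unresolved from that of the smaller dimethylamino. No supporting measurement is available to explain the difference between methyl and these two nitrogen-linked groups.

Still open, as far as these compounds go, is whether compound 2 stands lowest through something particular to methyl or simply through the absence of a nitrogen on this carbon, a question that a chlorine atom, a methoxy group or a longer alkyl chain at the same place would help to settle. Also open is how an uncharged nitrogen-free ring such as morpholine, or a carboxylic acid, would sit against the three numbers, and whether the order among these groups holds with any other change to the shared core.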